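The compounds below may be only part of what the source reports. "The series", "measured", "known", "first", "only" and "open" are said of these compounds alone.

Compound 2 `O=C1c2c[n+]([O-])c3ccccc3c2C(=O)c2[nH]c3ccccc3c21` carries a hydrogen on the aromatic nitrogen of its five-membered ring, and in a functional assay on SH-SY5Y cells (Homo sapiens) for cytotoxicity, read by MTT assay, with a stated time of 72 h (on this read-out lower numbers stand for stronger inhibition and higher numbers for weaker inhibition), compound 2 gives 1380 nM, the highest of the two plain numbers recorded. Compound 1 `O=C1c2c[n+]([O-])c3ccccc3c2C(=O)c2c1c1ccccc1n2Cc1cn([C@H]2C[C@H](O)[C@@H](CO)O2)nn1` gives 620 nM in this assay, a value that sits beyond the scatter below that of compound 2. For compound 3 `CC1(C)OC[C@@H](Cn2cc(Cn3c4c(c5ccccc53)C(=O)c3c[n+]([O-])c5ccccc5c3C4=O)nn2)O1` this assay returns only a limit, > 1000 nM (the limit of > 1000 nM in this assay, at which 1 of the 3 values shown sits). For the measured compounds named here, the one measured step, an at least 1.6-fold higher number from compound 1 to compound 3 (0.20 log units; that floor lies within the scatter), alters a substituent elsewhere and does not test the nitrogen changed here. Compound 4 `CN1CCN(CCCn2c3c(c4ccccc42)C(=O)c2c[n+]([O-])c4ccccc4c2C3=O)CC1` arises from compound 2 by 3-(4-methylpiperazin-1-yl)propyl in place of hydrogen on an aromatic nitrogen. Since compound 1 lies lower than compound 2, compound 4 is expected to give a somewhat lower number, a 2.1-fold lower number from compound 2 to compound 4 (0.33 log units; beyond the scatter), in this assay, estimated at 650 nM within 250 nM to 1600 nM.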

Compound 4, half-maximal inhibitory concentration: 560 nM
Compound 4: the middle estimate sits 1.2-fold (0.06 log units) above what was measured, and the stated range covers the measured number.
By their numbers in this assay, from the lowest: compounds 4 and 1 (each within the scatter of the next); then compound 2.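

At the aromatic nitrogen itself, 3-(4-methylpiperazin-1-yl)propyl in place of hydrogen gives a 2.5-fold lower number from compound 2 to compound 4 (0.39 log units; beyond the scatter) in this assay, the only step shown that tests this position. The hydrogen on this nitrogen is therefore not needed for activity on this read-out, and a substituent ending in a six-membered non-aromatic ring is accepted there. Nothing measured here accounts for the modest change.

The compounds shown leave open whether the piperazine ring matters or whether any substituent would do. A plain methyl group, or a propyl chain ending in a morpholine or a primary amine, would separate these readings.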